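A few compounds are considered here, and "the series" means these few. Any claim that something is new, unique, unknown or untested is made for them only; others in the source may bear on it.

Measured so far in a physicochemical assay for solubility, in phosphate buffer, with a stated time of 18 h, at pH 7; on this read-out lower numbers stand for lower solubility and higher numbers for higher solubility:
- compound 1 `CC(C)CN1C(=O)c2ccccc2[C@H](C(=O)Nc2ccc(F)c(C#N)c2)[C@H]1c1ccc(C#N)s1`: 4900 nM
- compound 2 `CC(C)CN1C(=O)c2ccccc2[C@H](C(=O)Nc2ccc(F)c(C#N)c2)[C@H]1c1cncc(C#N)c1`: 60000 nM

Compound 2 holds the higher of the two numbers, and its gap to compound 1 lies beyond the usual scatter. The next structure is compound 3 `CC(C)CN1C(=O)c2ccccc2[C@H](C(=O)Nc2ccc(F)c(C#N)c2)[C@H]1c1ccno1`, which has 1,2-oxazol-5-yl in place of 5-cyanopyridin-3-yl on a saturated ring carbon, next to the ring nitrogen: 1,2-oxazol-5-yl in place of 5-cyanopyridin-3-yl on a saturated ring carbon.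

Within the data shown here, only one measured step bears on this change: a 12-fold higher number from compound 1 to compound 2 (1.09 log units; beyond the scatter). It is a large step at the same carbon, so the group at this place can clearly move the number in this assay. It offers no direct reading for 1,2-oxazol-5-yl, however, so the direction remains an expectation. Compound 1, at 4900 nM, also carries a five-membered aromatic ring there, which points to a fall from compound 2, though a smaller one than the measured step. The expected change is a 3.0-fold lower number from compound 2 to compound 3 (0.48 log units; beyond the scatter). For compound 3 the estimated value is 20000 nM, with an expected range of 6000 nM to 70000 nM.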

Compound 3, solubility: 53000 nM
Estimate against measurement, compound 3: 2.7-fold (0.42 log units) below, within the range that was stated.
By their numbers in this assay, from the lowest: compound 1; then compounds 3 and 2 (each within the scatter of the next).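

In this assay, putting 1,2-oxazol-5-yl at the saturated ring carbon in place of 5-cyanopyridin-3-yl gives a 1.1-fold lower number from compound 2 to compound 3 (0.05 log units; within the scatter), so this change leaves compounds 2 and 3 indistinguishable even though the aromatic ring goes from six-membered to five-membered and the nitrile is lost. The other new step, an 11-fold higher number from compound 1 to compound 3 (1.03 log units; beyond the scatter), is large and shows that a five-membered aromatic ring at this carbon does not by itself go with the number of compound 1; among these three compounds, compound 1 alone stands apart. Nothing available offers a measured reason for that separation.

On these data alone, the step between compounds 1 and 3 changes the ring and removes the nitrile together, so it remains open whether the thiophene ring, its nitrile or their combination sets compound 1 apart. Also open, as far as these compounds go, is how this assay would respond to a plain thiophen-2-yl group, or to an amine or a carboxylic acid on the aromatic ring at this carbon.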